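The compounds below may be only part of what the source reports. "The series", "measured", "known", "first", "only" and "open" are said of these compounds alone.

Measured so far:
Compound 1, `COc1ccc(/C=N/NC(=S)NC(C)(C)[C@H]2CC=C(C)CC2)cc1`, gives 1500 nM in a functional assay on K562 cells (Homo sapiens) for inhibition, read by sulforhodamine B assay, with a stated time of 48 h; a higher number here means a weaker inhibitor of growth, a lower number a stronger inhibitor of growth.
Compound 2, `CC1=CC[C@H](C(C)(C)NC(=S)N/N=C/c2ccc(N(C)C)cc2)CC1`, gives 22600 nM in this assay.

Compound 2 stands highest of the two numbers in this assay; its nearest neighbour is compound 1, and the step of a 15-fold higher number from compound 1 to compound 2 (1.18 log units; beyond the scatter) lies well beyond the scatter. Compound 3, `CC1=CC[C@H](C(C)(C)NC(=S)N/N=C/c2ccc(F)cc2)CC1`, has not yet been measured in this assay. It differs from compound 2 in one place: fluoro in place of dimethylamino on an aromatic carbon. Among the compounds with values here, only one measured step bears on this position, the change from methoxy to dimethylamino, a 15-fold higher number from compound 1 to compound 2 (1.18 log units; beyond the scatter), which was large. Fluoro is neither of those two groups, so the direction of that step gives no direct guide, yet it shows that the group at this aromatic carbon moves the number strongly. A return toward the range of compound 1 is therefore expected, and the estimated step is a 6.5-fold lower number from compound 2 to compound 3 (0.81 log units; beyond the scatter). Compound 3 is expected to give about 3500 nM, between 900 nM and 15000 nM.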

Compound 3, concentration for 50% growth inhibition: > 100000 nM
Compound 3: no number, only a limit; the forecaster's own chance of this, stated with the estimate: 5%; middle value at least 28-fold (1.45 log units) from the limit.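

In this assay compound 3 gives > 100000 nM, which is a limit of the assay and not a number. Fluoro in this place, on an aromatic carbon para to a large group, therefore does not bring the number back toward that of the methoxy compound: against methoxy the change gives an at least 66-fold higher number from compound 1 to compound 3 (1.82 log units; beyond the scatter), and against dimethylamino it gives an at least 4.4-fold higher number from compound 2 to compound 3 (0.64 log units; beyond the scatter). The earlier pair showed only that this position matters, whereas compound 3 now stands as the weakest inhibitor of growth of the three, and removing dimethylamino alone does not recover the activity of compound 1.

As far as these compounds go, how far compound 3 lies past its limit stays unknown, so both steps give only a minimum size. From the compounds shown here alone, whether a hydroxyl, an ethoxy or a chlorine atom at this carbon would keep a measurable number remains open.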